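The source may hold more compounds than are shown below. What is called first, only, known or untested is meant among the compounds shown, and "the series" means these compounds.

In an ADME assay on Vero cells (Chlorocebus sabaeus) for cytotoxicity (a higher number here means a weaker inhibitor, a lower number a stronger inhibitor), compound 2 `CC(C)(C)N1C(=O)c2cccnc2C1=O` gives 33000 nM. Compound 1 `CC(C)c1cccc(C(C)C)c1N1C(=O)c2nccnc2C1=O` gives 20000 nM in this assay, and the gap between compound 2 and compound 1 lies within the scatter of repeated measurements, so the two stand side by side rather than apart. For compound 3 `O=C1c2nccnc2C(=O)N1Cc1ccccc1` this assay reports only a limit, > 100000 nM, which is a boundary of the measurement and not a number; this is the limit of > 100000 nM in this assay, at which 1 of the 3 values shown sits.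

Compound 4 `CCN1C(=O)c2cccnc2C1=O` has not been measured yet. It differs from compound 2 by ethyl in place of tert-butyl on an amide-type nitrogen in a ring: a shorter chain on the same amide-type nitrogen, with the fused two-ring core kept as it is. Within the data shown here, no pair among the measured compounds shows this kind of change, so the size of the step rests on expectation alone. Given how close compound 2 at 33000 nM sits to compound 1, the expected step from compound 2 to compound 4 is a 1.2-fold higher number from compound 2 to compound 4 (0.08 log units; within the scatter), a change not clearly beyond the scatter. The estimated value for compound 4 in this assay is 40000 nM, expected to fall between 15000 nM and 100000 nM.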

Compound 4, half-maximal inhibitory concentration: > 100000 nM
Compound 4 ended at the assay's limit; the forecaster's own chance of this, stated with the estimate: 35%; middle value at least 2.5-fold (0.39 log units) from the limit.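

On the amide-type nitrogen in the ring, ethyl in place of tert-butyl gives, in this assay, an at least 3.0-fold higher number from compound 2 to compound 4 (0.48 log units; beyond the scatter). Among these compounds, this is the first single change whose size can be read, and it shows that the group at this position matters for this read-out, with the shorter chain giving the higher number. The value of compound 4 is a limit and not a number, so the step is only a minimum and its true size stays unknown: the limit of > 100000 nM in this assay, at which 2 of the 4 values shown sit.

Among the compounds shown here, with only two groups to compare at this position on this core, it remains open whether the number follows the size of the group in a steady way. An isopropyl group or a longer chain such as butyl on the same nitrogen could show where between tert-butyl and ethyl the change sets in.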